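This account rests on a few compounds, and the source may have more. Where it says the series, first, only, none or still open, it means among the compounds named here.

Compound 1 `COc1cccc(C(=O)Nc2cc(-c3ccccc3)nn2-c2ccccc2)c1` gives 1290 nM in an assay on HEK293 cells for displacement of a labelled ligand from metabotropic glutamate receptor 5 (Rattus norvegicus); on this read-out lower numbers stand for stronger inhibition and higher numbers for weaker inhibition; compound 3 `O=C(Nc1cc(-c2ccccc2)nn1-c1ccccc1F)c1ccccc1` gives 2700 nM. Compound 2 `NC(=O)c1ccc(C(=O)Nc2cc(-c3ccccc3)nn2-c2ccccc2)cc1` is reported in this assay only as a limit, > 10000 nM.

Among the numbers shown, compound 3 stands highest, with compound 1 lower than it, while compound 2 sits at the limit of > 10000 nM in this assay, at which 1 of the 3 values shown sits. Compound 4 `O=C(Nc1cc(-c2ccccc2)nn1-c1cccc(Br)c1)c1ccccc1` differs from compound 3 in one place: 3-bromophenyl in place of 2-fluorophenyl on an aromatic nitrogen. Among the compounds with values here, the only measured step, an at least 7.7-fold higher number from compound 1 to compound 2 (0.88 log units; beyond the scatter), concerns a change on the carbonyl carbon and so does not bear on a change at the aromatic nitrogen; no measured pair varies that group alone. Compound 4 is therefore expected to lie near compound 3, estimated at 2500 nM, within 600 nM to 9000 nM. The expected step is a 1.1-fold lower number from compound 3 to compound 4 (0.03 log units; within the scatter), not beyond the scatter.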

Compound 4, inhibition constant: > 10000 nM
Compound 4 was reported as a limit (the forecaster's own chance of this, stated with the estimate: 20%); middle value at least 4.0-fold (0.60 log units) from the limit.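

Within the data shown here, on the aromatic nitrogen, 3-bromophenyl in place of 2-fluorophenyl gives an at least 3.7-fold higher number from compound 3 to compound 4 (0.56 log units; beyond the scatter) in this assay, so this position, which no earlier pair varied, responds to its substituent. The two groups have the same count of heavy atoms and neither has a hydrogen-bond donor or acceptor, yet the step lies beyond the scatter. The value of compound 4 is a limit, not a number: the limit of > 10000 nM in this assay, at which 2 of the 4 values shown sit.

The step swaps the halogen and its place on the ring together, and the compounds shown do not separate the two. On these data alone, how a 3-fluorophenyl or a 2-bromophenyl on this nitrogen reads remains open.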